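The source may hold more compounds than are shown below. What is called first, only, known or untested is meant among the compounds shown, and "the series" means these compounds.

Compound 3 `O=C(/C=C/c1ccc(OCc2nc(C3CCN(Cc4ccccc4F)CC3)no2)cc1)NO` stands level with compound 2 `Cc1ccccc1CN1CCC(c2noc(COc3ccc(/C=C/C(=O)NO)cc3)n2)CC1` in an assay on isolated protein for inhibition of protein deacetylase HDAC6 (Homo sapiens), read by fluorescence, with a stated time of 1 h, tested at 100 nM; a lower number here means less inhibition, a higher number more inhibition at the concentration tested (going by the name of the read-out): compound 3 gives 68% and compound 2 gives 68%, together the highest of the three numbers, while compound 1 `C=CCN1CCC(c2noc(COc3ccc(/C=C/C(=O)NO)cc3)n2)CC1` gives 66%, within the scatter of both. Compound 4 `O=C(/C=C/c1ccc(OCc2nc(C3CCN(Cc4cccc(F)c4)CC3)no2)cc1)NO` differs from compound 3 in a single place: 3-fluorophenyl in place of 2-fluorophenyl on a saturated chain carbon bound to an amine nitrogen in a ring. Earlier swaps at this same saturated chain carbon bound to an amine nitrogen in a ring moved little: a number 2 percentage points higher from compound 1 to compound 3 (within the scatter), no change at the digits printed from compound 2 to compound 3 (within the scatter), and a number 2 percentage points higher from compound 1 to compound 2 (within the scatter). Each of those changes stayed inside the scatter, so the expected step of no change at the digits printed from compound 3 to compound 4 (within the scatter) is no change beyond the scatter. Compound 4 is therefore estimated to give about 68% in this assay, between 58% and 78%.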

Compound 4, a percentage reported as inhibition, at one concentration (the size of the read-out at that concentration, not a potency): 73%
Compound 4: middle estimate off by 5 percentage points, on the low side; the measured number falls inside the stated range.
By their numbers in this assay, from the lowest: compounds 1, 2, 3 and 4 (each within the scatter of the next).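

In this assay, putting 3-fluorophenyl in place of 2-fluorophenyl gives a number 5 percentage points higher from compound 3 to compound 4 (within the scatter), so moving the fluoro around the phenyl ring is not shown to matter at this saturated chain carbon. The other two steps, a number 5 percentage points higher from compound 2 to compound 4 (within the scatter) and a number 7 percentage points higher from compound 1 to compound 4 (within the scatter), also stay inside the scatter, so even vinyl and 3-fluorophenyl cannot be told apart here. No evidence bears on these small differences. Still open, going by these compounds, is whether 4-fluorophenyl, or a longer chain ending in an amine, would move the number beyond the scatter.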